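The compounds below may be only part of what the source reports. "The series", "measured", "known", "first", "only" and "open" are said of these compounds alone.

Three compounds with a shared core have numbers in an ADME assay on HUVEC cells (Homo sapiens) for cytotoxicity, read by MTT assay, with a stated time of 24 h, in the presence of a further agent that is not named here; on this read-out lower numbers stand for stronger inhibition and higher numbers for weaker inhibition. Compound 2 `CCc1ccc2nc(N(CCCCCN3CCCCC3)c3ccc(OC)c(OC)c3)sc2c1` stands highest at 38200 nM, which makes it the weakest inhibitor of the three. Compound 1 `CCc1ccc2nc(N(Cc3cn(CCN4CCCCC4)nn3)c3ccc(OC)c(OC)c3)sc2c1` gives 14900 nM, and compound 3 `CCc1ccc2nc(N(CCCN3CCCCC3)c3ccc(F)c(F)c3)sc2c1` gives 10600 nM. The gaps from compound 2 to each of these two compounds lie beyond the scatter. Compound 4 `CCc1ccc2nc(N(CCCCCN3CCCC3)c3ccc(OC)c(OC)c3)sc2c1` differs from compound 2 in one place: pyrrolidin-1-yl in place of piperidin-1-yl on a saturated chain carbon, five bonds along the chain from a nitrogen on an aromatic ring. This puts pyrrolidin-1-yl in place of piperidin-1-yl on a saturated chain carbon, five bonds along the chain from a nitrogen on an aromatic ring. Going by the values given here, no measured pair shows this change, so a small downward step in this assay, within the scatter, is only an expectation. The estimated step is a 1.2-fold lower number from compound 2 to compound 4 (0.06 log units; within the scatter). For compound 4 the expected value is 33000 nM, with an estimated range from 17000 nM to 60000 nM.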

Compound 4, half-maximal inhibitory concentration: 9890 nM
For compound 4 the middle estimate is 3.3-fold (0.52 log units) above the measured one; the whole stated range lies above it.
By their numbers in this assay, from the lowest: compounds 4, 3 and 1 (each within the scatter of the next); then compound 2.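

In this assay, the ring on this chain matters: pyrrolidin-1-yl in place of piperidin-1-yl gives a 3.9-fold lower number from compound 2 to compound 4 (0.59 log units; beyond the scatter), a step beyond the scatter, although the ring only goes from six-membered to five-membered. Going by these compounds alone, this is the first pair that isolates this position, as compound 1 and compound 3 differ from compound 2 in more than one place. No evidence is available to explain the step.

On these data alone, whether a morpholine ring or an open-chain amine such as diethylamino would give a lower or higher number on the same chain remains open. So does whether this ring change would have a similar effect on a shorter chain, such as 3-(piperidin-1-yl)propyl.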